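Aryl exchange on the shared core: compound 2 to compound 3

This account rests on a few compounds, and the source may have more. Where it says the series, first, only, none or still open, it means among the compounds named here.

Measured so far:
compound 1 `CCS(=O)(=O)Nc1cc(-c2ccc3ncnc(Nc4ccc(OC)cc4)c3c2)cnc1OC` — 3490 nM
compound 2 `CCS(=O)(=O)Nc1cc(-c2ccc3ncnc(Nc4ccc(Cl)c(C(=O)OC)c4)c3c2)cnc1OC` — 3130 nM

In a functional assay on HCT-116 cells (Homo sapiens) for cytotoxicity, read by sulforhodamine B assay, with a stated time of 72 h (a lower number here means a stronger inhibitor, a higher number a weaker inhibitor), compound 1 gives 3490 nM and compound 2 gives 3130 nM. Compound 2 stands at the lower of the two recorded numbers, but the step of a 1.1-fold lower number from compound 1 to compound 2 (0.05 log units; within the scatter) lies within the scatter, so the two compounds cannot be told apart on this assay.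

Compound 3 `CCS(=O)(=O)Nc1cc(-c2ccc3ncnc(Nc4ccc(C(=O)OC)c(OC)c4)c3c2)cnc1OC` awaits measurement in this assay. Its change from compound 2: 3-methoxy-4-(methoxycarbonyl)phenyl in place of 4-chloro-3-(methoxycarbonyl)phenyl on a nitrogen on an aromatic ring. Among the compounds with values here, the only measured step at the same nitrogen is the one from compound 1 to compound 2, a 1.1-fold lower number from compound 1 to compound 2 (0.05 log units; within the scatter), an exchange of the whole aryl group that stayed within the scatter. A further exchange at that nitrogen is therefore expected to give a step of about a 1.0-fold higher number from compound 2 to compound 3 (0.01 log units; within the scatter), not beyond the scatter. Compound 3 is estimated at 3200 nM, with a range of 1400 nM to 7500 nM.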

Compound 3, half-maximal inhibitory concentration: 1690 nM
Compound 3: the middle estimate sits 1.9-fold (0.28 log units) above what was measured, within the range that was stated.
By their numbers in this assay, from the lowest: compounds 3, 2 and 1 (each within the scatter of the next, the first and the last beyond it).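

In this assay, exchange of the aryl group on the nitrogen now gives its first step beyond the scatter: 3-methoxy-4-(methoxycarbonyl)phenyl in place of 4-methoxyphenyl gives a 2.1-fold lower number from compound 1 to compound 3 (0.31 log units; beyond the scatter), a modest step. Against 4-chloro-3-(methoxycarbonyl)phenyl the same group gives a 1.9-fold lower number from compound 2 to compound 3 (0.27 log units; within the scatter), so these two aryl groups cannot be told apart here, and compound 2 cannot be separated from either of the other two compounds. Nothing measured here bears on the reason for the step at this nitrogen.

Open, on these data alone, is whether the methoxycarbonyl group itself carries the step or whether the other substituents on the aryl ring do. A carboxylic acid or an amide in place of the methoxycarbonyl group, or an unsubstituted phenyl on the same nitrogen, would help separate these readings.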